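A few compounds are considered here, and "the series" means these few. Any claim that something is new, unique, unknown or untested is made for them only; others in the source may bear on it.

Of the compounds shown here, three with a shared core have been measured in a functional assay on A549 cells (Homo sapiens) for antiproliferative activity, read by MTT assay, with a stated time of 48 h; on this read-out higher numbers stand for weaker inhibition and lower numbers for stronger inhibition. Compound 1 (`CC(C)=CCC[C@]1(C)/C=C/[C@@H](OC(=O)C=C(C)C)[C@](C)(O)/C=C/C(=O)/C(CN(C)C)=C\C1`) gives 590 nM, compound 2 (`CO/N=C/C1=C/C[C@](C)(CCC=C(C)C)/C=C/[C@@H](OC(=O)C=C(C)C)[C@](C)(O)/C=C/C1=O`) gives 3470 nM, and compound 3 (`CC(C)=CCC[C@]1(C)/C=C/[C@@H](OC(=O)C(C)C)[C@](C)(O)/C=C/C(=O)/C(CO)=C\C1`) gives 10800 nM. That last value is the highest of the three numbers, so compound 3 is the weakest inhibitor so far.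

Compound 4 (`COCO[C@@H]1/C=C/[C@@](C)(CCC=C(C)C)C/C=C(/CO)C(=O)/C=C/[C@@]1(C)O`) has not been measured yet. It differs from compound 3 in one place: methoxymethyl in place of isopropylcarbonyl on an oxygen on a saturated carbon. In words, methoxymethyl stands in place of isopropylcarbonyl on an oxygen on a saturated carbon.

Among the compounds with values here, only one measured step links two compounds that differ in a single place, a 5.9-fold higher number from compound 1 to compound 2 (0.77 log units; beyond the scatter). Within the data shown here, that change lies on a double-bonded ring carbon, not on this oxygen, so it shows only that one swap can move the number beyond the scatter. Among the measured compounds shown here, no measured pair tests the change at this oxygen, so no direction can be argued, and no step beyond the scatter is expected in this assay. The expected step is a 1.1-fold higher number from compound 3 to compound 4 (0.05 log units; within the scatter), a small one that remains uncertain. For compound 4 the estimated value is 12000 nM, with an expected range of 4000 nM to 36000 nM.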

Compound 4, half-maximal inhibitory concentration: > 40000 nM
Compound 4 gave a limit, no number; the forecaster's own chance of this, stated with the estimate: 15%; middle value at least 3.3-fold (0.52 log units) from the limit.
By their numbers in this assay, from the lowest: compound 1; then compound 2; then compound 3. At a limit, above all of these: compound 4.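

Within the data shown here, this is the first measured change at this oxygen on a saturated carbon, and in this assay swapping isopropylcarbonyl for methoxymethyl gives an at least 3.7-fold higher number from compound 3 to compound 4 (0.56 log units; beyond the scatter). Until now, the only single-place step lay on a double-bonded ring carbon, so the group on this oxygen is now shown to matter as well. Compound 4 gave a limit and not a number, so its step has a floor but no known full size: the limit of > 40000 nM in this assay, at which 1 of the 4 values shown sits.

The group that leaves has a double bond and the group that enters has none, but this single pair cannot show whether that difference is what counts. From the compounds shown here alone, it also remains open how an acetyl group, a longer acyl chain such as octanoyl, or an amine-bearing chain on this oxygen would compare with isopropylcarbonyl.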